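The compounds below may be only part of what the source reports. "The series", "measured", "known", "first", "only" and "open" are said of these compounds alone.

- compound 1 `CCc1ccc(-c2nc3c(c(C)nn3-c3ccccc3)c(-c3ccccc3)c2C#N)cc1`: 47000 nM
- compound 2 `CCc1ccc(-c2nc3c(c(C)nn3-c3ccccc3)c(-c3ccc(O)cc3)c2C#N)cc1`: 5700 nM
- compound 3 `Cc1ccc(-c2nc3c(c(C)nn3-c3ccccc3)c(-c3ccccc3O)c2C#N)cc1`: 26000 nM

These three values come from a physicochemical assay for solubility, read by spectrophotometry, in phosphate buffer, with a stated time of 18 h, at pH 7.4; a higher number here means a more soluble compound, a lower number a less soluble compound. Compound 3 stands second of the three numbers at 26000 nM. That value lies within the usual scatter of compound 1, and both stand clearly above compound 2.

The next compound, compound 4 `Cc1ccccc1-c1nc2c(c(C)nn2-c2ccccc2)c(-c2ccccc2O)c1C#N`, has the same atoms as compound 3, joined differently: 2-methylphenyl in place of 4-methylphenyl on an aromatic carbon. For the measured compounds named here, no measured step moves a methyl group, so nothing here bears directly on this change. Going by the values given here, the only measured step, an 8.2-fold lower number from compound 1 to compound 2 (0.92 log units; beyond the scatter), adds a hydroxy group elsewhere on the molecule. Among the compounds with values here, it shows only that one small change can matter, and so the range is kept wide. No step beyond the scatter is expected in this assay, and neither direction is favoured much. The estimated step is a 1.2-fold higher number from compound 3 to compound 4 (0.06 log units; within the scatter). For compound 4 the estimated value is 30000 nM, with an expected range from 11000 nM to 80000 nM.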

Compound 4, solubility: 21000 nM
Estimate against measurement, compound 4: 1.4-fold (0.15 log units) above; measured number inside the range.
By their numbers in this assay, from the lowest: compound 2; then compounds 4, 3 and 1 (each within the scatter of the next, the first and the last beyond it).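

In this assay, for the compounds shown here, the step of a 1.2-fold lower number from compound 3 to compound 4 (0.09 log units; within the scatter) is the first measured change at the aryl group next to the ring nitrogen and ortho to a cyano group. Moving the methyl group, from 4-methylphenyl to 2-methylphenyl, keeps the same atoms and stays within the scatter, whereas the step of an 8.2-fold lower number from compound 1 to compound 2 (0.92 log units; beyond the scatter) adds a hydroxy group elsewhere on the molecule and lies beyond it. No measurement given here accounts for the close agreement between these two arrangements.

From the compounds shown here alone, only these two places for the methyl group are compared, so it stays open whether 3-methylphenyl would also fall within the scatter of them. Going by these compounds, it is also open whether an amine or a carboxylic acid on this same aryl ring would give a step beyond the scatter.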